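Compound 3 in human microsomes: a ring exchange

A few compounds are considered here, and "the series" means these few. Any claim that something is new, unique, unknown or untested is made for them only; others in the source may bear on it.

Measured so far:
compound 1 `CC#C[C@@H](Cc1nnn[nH]1)c1ccc(OCc2ccc3scc(-c4cc(OCCOC)ccc4C)c3c2)cc1` gives 0.867 h
compound 2 `CC#C[C@@H](Cc1nnn[nH]1)c1ccc(OCc2ccc3scc(-c4ccc(OCCOC)cc4C)c3c2)cc1` gives 0.717 h

In an ADME assay on microsomes from liver (Homo sapiens) for metabolic stability (on this read-out higher numbers stand for a longer-lived compound and lower numbers for a shorter-lived compound), compound 2 gives 0.717 h, and this lies within the usual scatter of compound 1 at 0.867 h. Compound 3 `CC#C[C@@H](Cc1nnn[nH]1)c1ccc(OCc2ccc3scc(-c4cncnc4C)c3c2)cc1` has not yet been measured. It carries 4-methylpyrimidin-5-yl in place of the 4-(2-methoxyethoxy)-2-methylphenyl of compound 2, on an aromatic carbon of the five-membered aromatic ring with 1 sulfur, two ring bonds from the ring sulfur: 4-methylpyrimidin-5-yl in place of 4-(2-methoxyethoxy)-2-methylphenyl on an aromatic carbon.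

Among the compounds with values here, only one measured step bears on this, and only loosely: a 1.2-fold lower number from compound 1 to compound 2 (0.08 log units; within the scatter), which is within the scatter. That step keeps the six-membered aromatic ring of carbon only and the 2-methoxyethoxy chain, so it gives no measure of an exchange like this one. The expectation in this assay therefore rests on the structural change alone and is weakly held: a modest rise, with a result inside the scatter quite possible. The estimated change is a 1.5-fold higher number from compound 2 to compound 3 (0.19 log units; within the scatter). Compound 3 is expected at 1.1 h, with an estimated range of 0.45 h to 2.8 h.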

Compound 3, half-life: 0.233 h
Beside the measured number, compound 3's estimate is 4.7-fold (0.67 log units) above it; measured number below the stated range.
By their numbers in this assay, from the lowest: compound 3; then compounds 2 and 1 (each within the scatter of the next).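

Working notes: at the aromatic carbon two ring bonds from the ring sulfur, the group can move the read-out beyond the scatter in this assay, which the pair of chain-bearing compounds did not show. The exchange gives a 3.1-fold lower number from compound 2 to compound 3 (0.49 log units; beyond the scatter), and measured against the 5-(2-methoxyethoxy)-2-methylphenyl group it gives a 3.7-fold lower number from compound 1 to compound 3 (0.57 log units; beyond the scatter), so the direction is the same from either chain-bearing compound. Nothing measured here accounts for this loss of half-life.

The exchange replaces the six-membered aromatic ring of carbon only with one carrying 2 hetero atoms and also removes the 2-methoxyethoxy chain, so the compounds shown leave open which of these changes goes with the lower number. A plain 2-methylphenyl group, a 4-methylpyrimidin-5-yl group carrying a 2-methoxyethoxy chain, or a methylpyridinyl group with a single ring nitrogen would separate these contributions in this assay.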